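Cinnamamide series on the benzophenone core: fluorophenyl step

This account rests on a few compounds, and the source may have more. Where it says the series, first, only, none or still open, it means among the compounds named here.

Compound 1 `COc1ccc(C(=O)c2cc(OC)c(OC)c(OC)c2)cc1NC(=O)/C=C/c1cc(OC)c(OC)c(OC)c1` and compound 2 `COc1ccc(C(=O)c2cc(OC)c(OC)c(OC)c2)cc1NC(=O)/C=C/c1ccc(C(F)(F)F)cc1` share a core and differ on the double-bonded chain carbon bound to a double-bonded chain carbon. In a functional assay on COLO 205 cells (Homo sapiens) for cytotoxicity, read by MTT assay, with a stated time of 72 h (on this read-out lower numbers stand for stronger inhibition and higher numbers for weaker inhibition), compound 1 gives 5200 nM and compound 2 gives 2600 nM; the step of a 2.0-fold lower number from compound 1 to compound 2 (0.30 log units; within the scatter). Compound 3 `COc1ccc(/C=C/C(=O)Nc2cc(C(=O)c3cc(OC)c(OC)c(OC)c3)cc(OC)c2OC)cc1OC` carries its amide on a differently substituted core and gives 5700 nM in this assay. Compound 3 and compound 1 lie within the scatter of each other; compound 3 stands beyond the scatter above compound 2, which gives the lowest number of the three.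

Compound 4 `COc1cc(C(=O)c2cc(OC)c(OC)c(OC)c2)cc(NC(=O)/C=C/c2ccc(F)cc2)c1OC` is not yet measured. It differs from compound 3 by 4-fluorophenyl in place of 3,4-dimethoxyphenyl on a double-bonded chain carbon bound to a double-bonded chain carbon. Going by the values given here, the only measured step at that place is the one from compound 1 to compound 2, where a methoxy-bearing ring gave way to a fluorine-bearing ring with a change within the scatter. On that basis the expected step for compound 4 in this assay is small, leaning toward a lower number, and the estimate for the step is a 1.6-fold lower number from compound 3 to compound 4 (0.21 log units; within the scatter). Compound 4 is therefore estimated at 3500 nM, within a range from 1500 nM to 9000 nM in this assay.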

Compound 4, half-maximal inhibitory concentration: 3100 nM
Estimate against measurement, compound 4: 1.1-fold (0.05 log units) above; the measured number falls inside the stated range.
By their numbers in this assay, from the lowest: compounds 2, 4, 1 and 3 (each within the scatter of the next, the first and the last beyond it).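

Working notes, position on the double-bonded chain carbon: in this assay the second step read here, on a different core from the first, is a 1.8-fold lower number from compound 3 to compound 4 (0.26 log units; within the scatter), so the 3,4-dimethoxyphenyl ring gives way to 4-fluorophenyl without a change beyond the scatter. Together with a 2.0-fold lower number from compound 1 to compound 2 (0.30 log units; within the scatter), this makes two steps at this place, on two cores and with two different ring pairs, and neither goes beyond the scatter; none of the listed compounds goes against this, though two steps are a thin base. No measurement on hand bears on why this place tolerates these ring changes.

On these data alone, the effect of 4-fluorophenyl against 4-(trifluoromethyl)phenyl on a single shared core stays open, as compound 2 and compound 4 differ in more than one place. Also open, as far as these compounds go, is how this place responds to a ring carrying an amine or a carboxylic acid, or to a saturated ring such as cyclohexyl, as all four compounds carry a six-membered aromatic ring of carbon only here.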